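A few compounds are considered here, and "the series" means these few. Any claim that something is new, unique, unknown or untested is made for them only; others in the source may bear on it.

Of the compounds shown here, two have been measured in a functional assay on HT-29 cells (Homo sapiens) for cytotoxicity, read by MTT assay, with a stated time of 72 h; on this read-out lower numbers stand for stronger inhibition and higher numbers for weaker inhibition. Compound 1, `COc1ccc(/C=C/C(=O)Nc2cc(C(=O)c3cc(OC)c(OC)c(OC)c3)ccc2OC)cc1`, gives 5010 nM in this assay. Compound 2, `COc1ccc(/C=C/C(=O)Nc2cc(C(=O)c3cc(OC)c(OC)c(OC)c3)cc(OC)c2OC)cc1OC`, gives 2300 nM in this assay, the lowest of the two numbers; compound 1 stands at a higher number, a gap that lies beyond the usual scatter. Among the measured compounds shown here, no step between measured compounds that differ in a single place is available, so the effect of any one change can only be inferred.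

Compound 3, `COc1ccc(/C=C/C(=O)Nc2cc(C(=O)c3cc(OC)c(OC)c(OC)c3)cc(OC)c2OC)cc1`, is compound 2 with one alteration: hydrogen in place of methoxy on an aromatic carbon. For the measured compounds named here, with no measured pair isolating this change, the account expects a small step from compound 2 to compound 3, towards a weaker or unchanged read-out, of a 1.4-fold higher number from compound 2 to compound 3 (0.14 log units; within the scatter). On that basis compound 3 is expected to give 3200 nM in this assay, with a range from 1300 nM to 8000 nM.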

Compound 3, half-maximal inhibitory concentration: 3800 nM
Beside the measured number, compound 3's estimate is 1.2-fold (0.07 log units) below it, and the stated range covers the measured number.
By their numbers in this assay, from the lowest: compounds 2, 3 and 1 (each within the scatter of the next, the first and the last beyond it).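

Taking one methoxy off the 3,4-dimethoxyphenyl group to leave a 4-methoxyphenyl group gives a 1.7-fold higher number from compound 2 to compound 3 (0.22 log units; within the scatter) in this assay and so stays within the scatter: at this position on the ethenyl side, hydrogen and methoxy cannot be told apart on this read-out. The other single change now readable, methoxy in place of hydrogen on an aromatic carbon, gives a 1.3-fold lower number from compound 1 to compound 3 (0.12 log units; within the scatter) and likewise stays within the scatter, so neither place is shown to matter on its own. Nothing is available here that would explain either step.

As far as these compounds go, whether a hydroxy group, a fluorine atom or an amine at this position would give a step beyond the scatter remains open. So does whether a longer alkoxy chain in place of either methoxy would read any differently.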